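Working notes: from compound 3 to compound 4

The source may report more compounds than this note shows. Statements on the series, on what has been measured and on what is new or still open speak of the compounds shown alone.

Measured so far in a functional assay on MCF7 cells (Homo sapiens) for antiproliferative activity, read by MTT assay, with a stated time of 48 h; a lower number here means a stronger inhibitor, a higher number a weaker inhibitor:
- compound 1 `CC(C)=CCC[C@]1(C)/C=C/[C@@H](OC(=O)C=C(C)C)[C@](C)(O)/C=C/C(=O)/C(CN(C)C)=C\C1` gives 690 nM
- compound 2 `CC(C)=CCC[C@]1(C)/C=C/[C@@H](OC(=O)C=C(C)C)[C@](C)(O)/C=C/C(=O)/C(CN(C(C)C)C(C)C)=C\C1` gives 780 nM
- compound 3 `CC(C)=CCC[C@]1(C)/C=C/[C@@H](OC(=O)C=C(C)C)[C@](C)(O)/C=C/C(=O)/C(CN2CCCC2)=C\C1` gives 220 nM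

Compound 3 holds the lowest number of the three, and its gaps to both others lie beyond the scatter. The next change leads to compound 4 `CC(C)=CCC[C@]1(C)/C=C/[C@@H](OC(=O)C=C(C)C)[C@](C)(O)/C=C/C(=O)/C(C[Si](C)(C)C(C)(C)C)=C\C1` and consists of a group of 7 heavy atoms (6 carbon, 1 silicon; no ring) in place of a group of 5 heavy atoms (4 carbon, 1 nitrogen; one five-membered non-aromatic ring with 1 hetero atom), on a saturated chain carbon bound to a double-bonded ring carbon in comparison with compound 3.

Among the compounds with values here, three measured steps bear on this place. Two are modest: a 3.1-fold lower number from compound 1 to compound 3 (0.50 log units; beyond the scatter) and a 3.5-fold lower number from compound 2 to compound 3 (0.55 log units; beyond the scatter). The third, a 1.1-fold higher number from compound 1 to compound 2 (0.05 log units; within the scatter), stays within the scatter. Within the data shown here, all three exchange one amino group for another, and no measured compound lacks nitrogen in this group, so the data bound this change only loosely.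

A modest step of similar size is expected in this assay, towards a higher number, since compound 3 at 220 nM is the lowest so far. The expected step is a 3.2-fold higher number from compound 3 to compound 4 (0.50 log units; beyond the scatter) as estimated. For compound 4 the estimate is 700 nM, with an expected range of 200 nM to 2500 nM in this assay.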

Compound 4, half-maximal inhibitory concentration: 6040 nM
The estimate for compound 4 lay 8.6-fold (0.94 log units) below the measured number; the whole stated range lies below it.
By their numbers in this assay, from the lowest: compound 3; then compounds 1 and 2 (each within the scatter of the next); then compound 4.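

In this assay the group of 7 heavy atoms (6 carbon, 1 silicon; no ring) carries no nitrogen and gives a 27-fold higher number from compound 3 to compound 4 (1.44 log units; beyond the scatter) as the largest step yet at this place. The step from an amine with the same heavy-atom count and no ring is a 7.7-fold higher number from compound 2 to compound 4 (0.89 log units; beyond the scatter) and the step from the smaller dimethylamino is an 8.8-fold higher number from compound 1 to compound 4 (0.94 log units; beyond the scatter) so all three amino compounds give lower numbers than compound 4, with no exception among the compounds shown. Heavy-atom count alone therefore does not order this series, since dimethylamino and diisopropylamino differ only by a 1.1-fold higher number from compound 1 to compound 2 (0.05 log units; within the scatter) while sharing nitrogen.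

Open, from the compounds shown here alone, is whether an all-carbon group such as neopentyl would track compound 4, or whether a piperidine or morpholine ring would track compound 3. No supporting data bear on what lies behind the rise at compound 4.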